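Para-trifluoromethyl phenoxy analogue in the amide series

This account rests on a few compounds, and the source may have more. Where it says the series, first, only, none or still open, it means among the compounds named here.

Measured so far:
compound 1, `CNC(=O)c1cccc(Cn2nc(C)c(NC(=O)c3ccc(COc4ccc(C)cc4)cc3)c2C)c1` — 2600 nM
compound 2, `CNC(=O)c1cccc(Cn2nc(C)c(NC(=O)c3ccc(COc4cccc(Cl)c4)cc3)c2C)c1` — 5900 nM

Both compounds were read in a functional assay on MIA PaCa-2 cells (Homo sapiens) for antiproliferative activity, read by MTT assay, with a stated time of 72 h; on this read-out lower numbers stand for an effect already at smaller amounts and higher numbers for an effect only at larger amounts of compound. Compound 2 gives the highest of the two numbers; its nearest neighbour is compound 1, and the step of a 2.3-fold higher number from compound 1 to compound 2 (0.36 log units; beyond the scatter) is the only one measured. Compound 3, `CNC(=O)c1cccc(Cn2nc(C)c(NC(=O)c3ccc(COc4ccc(C(F)(F)F)cc4)cc3)c2C)c1`, is not yet measured. It differs from compound 2 by 4-(trifluoromethyl)phenyl in place of 3-chlorophenyl on an oxygen on a saturated carbon. Going by the values given here, no measured step involves a trifluoromethyl group, so the change is only loosely covered: the one known step, from a para-substituted to a meta-substituted phenyl, was modest in size. Compound 3 returns to a para-substituted phenyl, so a modest step back in the direction of compound 1 is expected, a 1.5-fold lower number from compound 2 to compound 3 (0.17 log units; within the scatter), though a result within the scatter would not be surprising. For compound 3 the estimate in this assay is 4000 nM, with a range from 1500 nM to 11000 nM.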

Compound 3, half-maximal effective concentration: 800 nM
For compound 3 the middle estimate is 5.0-fold (0.70 log units) above the measured one, outside the stated range (below it).
By their numbers in this assay, from the lowest: compound 3; then compound 1; then compound 2.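

In this assay the step of a 3.3-fold lower number from compound 1 to compound 3 (0.51 log units; beyond the scatter) comes with trifluoromethyl in place of methyl on an aromatic carbon, so at this one place the choice of group alone moves the number beyond the scatter. The step of a 7.4-fold lower number from compound 2 to compound 3 (0.87 log units; beyond the scatter) comes with 4-(trifluoromethyl)phenyl in place of 3-chlorophenyl on the same oxygen, and it changes both the group and where it sits on the phenyl, so it cannot be divided between the two changes. No measurement here bears on why these numbers shift.

The three compounds do not separate the identity of the group from its place on the phenyl. Going by these compounds, how a methoxy group, an amine or a carboxylic acid would read on the aromatic carbon carrying trifluoromethyl in compound 3 stays open.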